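Chloro for 2-fluorophenyl at the limit of the assay

A few compounds are considered here, and "the series" means these few. Any claim that something is new, unique, unknown or untested is made for them only; others in the source may bear on it.

In an ADME assay on HCT-116 cells (Homo sapiens) for cytotoxicity, read by CellTiter-Glo, with a stated time of 72 h (a lower number here means a stronger inhibitor, a higher number a weaker inhibitor), compound 1 (`COc1ccccc1-c1cccc(S(=O)(=O)N2CCC(N3CCC(C)CC3)CC2)c1`) reads > 5000 nM as a limit and not as a number. In this assay compound 2 (`CC1CCN(C2CCN(S(=O)(=O)c3cccc(-c4ccccc4F)c3)CC2)CC1`) also reads > 5000 nM as a limit and not as a number. Compound 2 therefore stands at the limit of > 5000 nM in this assay, at which 2 of the 2 values shown sit, and no number places it within the series. Within the data shown here, the only measured step is a step that the two limits leave unreadable from compound 1 to compound 2 and it sets no size for what follows. That step changed a single group on the ring that now leaves, so it gives no direct guide to the next change.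

Compound 3 (`CC1CCN(C2CCN(S(=O)(=O)c3cccc(Cl)c3)CC2)CC1`) follows from compound 2 through chloro in place of 2-fluorophenyl on an aromatic carbon and carries chloro in place of 2-fluorophenyl on an aromatic carbon, meta to a large group. No readable step supports a shift in either direction. The expected step is a step that the limit leaves unreadable from compound 2 to compound 3 and nothing beyond the scatter is expected in this assay for this change. The estimate for compound 3 is 8000 nM with an expected range of 5000 nM to 20000 nM and a further limit reading is the likeliest outcome.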

Compound 3, half-maximal inhibitory concentration: > 5000 nM
Compound 3: no number, only a limit (the forecaster's own chance of this, stated with the estimate: 90%); the middle value is on the limit's open side.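

In this assay, among these compounds, no step among compound 1, compound 2 and compound 3 can be read, as all three values are limits and not numbers: the limit of > 5000 nM in this assay, at which 3 of the 3 values shown sit.

The compounds shown leave open how far any of these changes moves the read-out, and what number each of the three compounds would take past that limit.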